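Thiophene in Place of Naphthyl on a Shared Core

The compounds below may be only part of what the source reports. "The series", "measured", "known", "first", "only" and "open" are said of these compounds alone.

Compound 2 `COc1cc(N2C(N)=C(C#N)C(c3ccc(OC)c4ccccc34)C3=C2CC(C)(C)CC3=O)cc(OC)c1OC` gives 10% in a functional assay on Ehrlich cells (Mus musculus) for cytotoxicity, tested at 10 ug/mL (on this read-out higher numbers stand for a stronger effect at the one concentration tested and lower numbers for a weaker effect), the second highest of the three numbers measured. Compound 1 `COc1cc(N2C(N)=C(C#N)C(c3c(O)ccc4ccccc34)C3=C2CC(C)(C)CC3=O)cc(OC)c1OC` gives 2% in this assay, within the scatter of compound 2, while compound 3 `COc1ccccc1C1C(C#N)=C(N)N(c2cc(OC)c(OC)c(OC)c2)C2=C1C(=O)CC(C)(C)C2` gives 30%, beyond the scatter above both. The three measured steps all turn on the group at the saturated ring carbon: a number 8 percentage points higher from compound 1 to compound 2 (within the scatter), a number 28 percentage points higher from compound 1 to compound 3 (beyond the scatter) and a number 20 percentage points higher from compound 2 to compound 3 (beyond the scatter).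

Compound 4 `COc1cc(N2C(N)=C(C#N)C(c3cccs3)C3=C2CC(C)(C)CC3=O)cc(OC)c1OC` differs from compound 2 in one place: thiophen-2-yl in place of 4-methoxynaphthalen-1-yl on a saturated ring carbon. Among the measured compounds shown here, no measured step exchanges a naphthyl group for a five-membered aromatic ring, so the data bear only indirectly. The steps beyond the scatter, from compound 1 and from compound 2 to compound 3, both went with a one-ring aromatic group entering in place of a two-ring one, and thiophen-2-yl is again a one-ring group. A rise of similar size is therefore expected, though only a modest one, because a number 8 percentage points higher from compound 1 to compound 2 (within the scatter) shows that the group at this carbon can also leave the number nearly unchanged. The expected step is a number 10 percentage points higher from compound 2 to compound 4 (within the scatter). Compound 4 is estimated at 20%, within a range from 2% to 40%.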

Compound 4, a percentage reported as activity, at one concentration (the size of the read-out at that concentration, not a potency): 5%
Estimate against measurement, compound 4: 15 percentage points above; the measured number falls inside the stated range.
By their numbers in this assay, from the lowest: compounds 1, 4 and 2 (each within the scatter of the next); then compound 3.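

In this assay, the exchange at this saturated ring carbon shows that a one-ring aromatic group does not by itself bring the higher number seen with 2-methoxyphenyl: thiophen-2-yl in place of 4-methoxynaphthalen-1-yl gives a number 5 percentage points lower from compound 2 to compound 4 (within the scatter), and thiophen-2-yl in place of 2-hydroxynaphthalen-1-yl gives a number 3 percentage points higher from compound 1 to compound 4 (within the scatter), while thiophen-2-yl in place of 2-methoxyphenyl gives a number 25 percentage points lower from compound 3 to compound 4 (beyond the scatter). The number of aromatic rings therefore does not sort these four compounds: compound 4, with its one five-membered ring, stays within the scatter of the two naphthyl compounds, and compound 3 alone stands apart from all the others. Nothing available bears on why the 2-methoxyphenyl group differs from the other three groups.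

The compounds shown leave open whether the separation of compound 3 goes with its six-membered ring or with the methoxy group on that ring, a question that a plain phenyl group or a 2-hydroxyphenyl group at this carbon would address. They also leave open whether a furan-2-yl group would stay with thiophen-2-yl, and, with one concentration tested, how these compounds compare in potency.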